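The compounds below may be only part of what the source reports. "The series", "measured", "known", "first", "only" and "open" are said of these compounds alone.

Measured so far in an ADME assay on microsomes from liver (Rattus norvegicus) for metabolic stability, using NADPH, with a stated time of 10 min; on this read-out higher numbers stand for a more stable compound and lower numbers for a less stable compound:
Compound 1 `NC(=O)NCCCCN(C[C@H]1Cc2ncccc2CN1)[C@H]1CCCc2cccnc21`: 1%
Compound 2 `c1cnc2c(c1)CN[C@@H](CN(CCCCNC1CCOCC1)[C@H]1CCCc3cccnc31)C2`: 49%

Compound 2, at 49%, holds the higher of the two numbers, and compound 1 lies far under it. Compound 3 `c1cnc2c(c1)CN[C@@H](CN(CCCC1CCNCC1)[C@H]1CCCc3cccnc31)C2` has not yet been measured. Its difference from compound 2 is this: piperidin-4-yl in place of ((oxan-4-yl)amino)methyl on a saturated chain carbon, three bonds along the chain from an amine nitrogen. In words, piperidin-4-yl stands in place of ((oxan-4-yl)amino)methyl on a saturated chain carbon, three bonds along the chain from an amine nitrogen.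

For the measured compounds named here, only one measured step bears on this change: a number 48 percentage points higher from compound 1 to compound 2 (beyond the scatter), a large step beyond the scatter, with oxan-4-yl in place of carbamoyl on an amine nitrogen. It shows that an exchange of a group in this series can move the read-out widely. However, it is a different exchange, and it does not settle a direction for the new one. The best guess therefore stays close to compound 2, with wide uncertainty on either side. The estimated step is a number 6 percentage points higher from compound 2 to compound 3 (within the scatter), so no change beyond the scatter is expected as the central case. For compound 3 the expected value is 55%, with an estimated range from 25% to 85%.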

Compound 3, percent of the compound remaining: 40%
For compound 3 the middle estimate is 15 percentage points above the measured one, within the range that was stated.
By their numbers in this assay, from the lowest: compound 1; then compounds 3 and 2 (each within the scatter of the next).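

In this assay the place on the saturated chain carbon, three bonds along the chain from an amine nitrogen, accepts quite different end groups: exchanging ((oxan-4-yl)amino)methyl for piperidin-4-yl gives a number 9 percentage points lower from compound 2 to compound 3 (within the scatter) and so leaves the two compounds indistinguishable on this read-out. Measured against the ureidomethyl group, piperidin-4-yl gives a number 39 percentage points higher from compound 1 to compound 3 (beyond the scatter) and thus joins the oxan-4-yl amine as a second end group far clear of compound 1, so among these three compounds the low number belongs to the urea alone, with none going against that reading. Nothing measured here explains either step.

The compounds shown leave open whether the ring nitrogen of piperidin-4-yl matters at all, since a cyclohexyl group or an oxan-4-yl group carried directly on the same chain would be needed to separate the ring from its hetero atom. They also leave open how a carboxylic acid, a simple primary amine or a longer chain would read at this place, and whether any end group can lift the number well clear of compound 2.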